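The source may report more compounds than this note shows. Statements on the series, on what has been measured and on what is new or still open speak of the compounds shown alone.

Compounds measured so far:
compound 1, `O[C@@H]1Cc2cc(F)ccc2N[C@H](c2ccccc2)C1`, in an ADME assay on THP-1 cells (Homo sapiens) for cytotoxicity, read by MTT assay, with a stated time of 72 h; a lower number here means that less compound is tolerated, a higher number that more compound is tolerated: > 300000 nM
compound 2, `O[C@@H]1Cc2ccccc2N[C@H](c2ccc(Cl)cc2)C1`, in this assay: 114000 nM
compound 3, `O[C@@H]1Cc2cc(Cl)ccc2N[C@H](c2ccc(Cl)cc2)C1`, in this assay: 49200 nM

The value of compound 1 is a limit of this assay, not a number. Among the numbers shown, compound 3 has the lowest; the nearest is compound 2, and the step of a 2.3-fold lower number from compound 2 to compound 3 (0.36 log units; beyond the scatter) places compound 3 beyond the usual scatter from compound 2.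

Compound 4 is `O[C@@H]1Cc2cc(F)ccc2N[C@H](c2ccc(Cl)cc2)C1`, not yet measured. Compound 4 differs from compound 3 in one place: fluoro in place of chloro on an aromatic carbon. For the measured compounds named here, the only measured step that bears on this place is the one from hydrogen to chloro, a 2.3-fold lower number from compound 2 to compound 3 (0.36 log units; beyond the scatter), which was modest. Fluoro is a different halogen at the same position, so the expected step is small: compound 4 is expected to land between compound 2 and compound 3, within the scatter of both, as a 1.6-fold higher number from compound 3 to compound 4 (0.21 log units; within the scatter). The estimate for compound 4 in this assay is 80000 nM, with a range from 35000 nM to 200000 nM.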

Compound 4, half-maximal cytotoxic concentration: 100000 nM
For compound 4 the middle estimate is 1.3-fold (0.10 log units) below the measured one; measured number inside the range.
By their numbers in this assay, from the lowest: compound 3; then compounds 4 and 2 (each within the scatter of the next). At a limit, above all of these: compound 1.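

In this assay, this aromatic carbon of the shared core tells the two halogens apart, with a 2.0-fold higher number from compound 3 to compound 4 (0.31 log units; beyond the scatter). Fluoro in place of hydrogen at the same carbon gives a 1.1-fold lower number from compound 2 to compound 4 (0.06 log units; within the scatter), so of the groups shown here, only chloro shifts the number beyond the scatter. On a second core, chloro in place of hydrogen gives an at least 3.0-fold lower number from compound 1 to compound 4 (0.47 log units; beyond the scatter), but this step starts from a value of compound 1 that is a limit of the assay: the limit of > 300000 nM in this assay, at which 1 of the 4 values shown sits.

From the compounds shown here alone, it remains open whether a group other than a halogen at this aromatic carbon, such as a methoxy group or an amine, would leave the number where hydrogen and fluoro do or shift it as chloro does. Bromo, the next halogen after chloro, would show whether the step from fluoro to chloro continues.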